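The compounds below may be only part of what the source reports. "The series", "measured", "known", "first", "only" and "open" are said of these compounds alone.

Working notes on the series in a functional assay on HUVEC cells (Homo sapiens), read by scintillation counting and thymidine incorporation, with a stated time of 24 h; a lower number here means a stronger inhibitor, a higher number a weaker inhibitor. On the shared core, only the group on a saturated chain carbon bound to a saturated ring carbon varies. Compound 1 (`CCC(C)n1ncn(-c2ccc(N3CCN(c4ccc(OC[C@@H]5CO[C@@](CN(C)C)(c6ccc(Cl)cc6Cl)O5)cc4)CC3)cc2)c1=O`) gives 1400 nM, compound 2 (`CCC(C)n1ncn(-c2ccc(N3CCN(c4ccc(OC[C@@H]5CO[C@@](CN6CCNCC6)(c6ccc(Cl)cc6Cl)O5)cc4)CC3)cc2)c1=O`) gives 608 nM and compound 3 (`CCC(C)n1ncn(-c2ccc(N3CCN(c4ccc(OC[C@@H]5CO[C@@](Cn6cnc(C(F)(F)F)n6)(c6ccc(Cl)cc6Cl)O5)cc4)CC3)cc2)c1=O`) gives 270 nM, the lowest number of the three.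

Compound 4 (`CCc1nccn1C[C@@]1(c2ccc(Cl)cc2Cl)OC[C@@H](COc2ccc(N3CCN(c4ccc(-n5cnn(C(C)CC)c5=O)cc4)CC3)cc2)O1`) is next: 2-ethyl-1H-imidazol-1-yl in place of 3-(trifluoromethyl)-1H-1,2,4-triazol-1-yl, (2-ethyl-1H-imidazol-1-yl in place of 3-(trifluoromethyl)-1H-1,2,4-triazol-1-yl on a saturated chain carbon bound to a saturated ring carbon).

For the measured compounds named here, three measured steps bear on this only indirectly. The change of dimethylamino to piperazin-1-yl gave a 2.3-fold lower number from compound 1 to compound 2 (0.36 log units; beyond the scatter). Installing the trifluoromethyl triazole gave a 5.2-fold lower number from compound 1 to compound 3 (0.71 log units; beyond the scatter) from dimethylamino and a 2.3-fold lower number from compound 2 to compound 3 (0.35 log units; beyond the scatter) from piperazin-1-yl. All three are modest but beyond the scatter. Going by the values given here, no measured step exchanges one five-membered aromatic ring for another, so the direction remains open. Compound 4 keeps such a ring, and no step beyond the scatter is expected in this assay. The expected step is a 1.3-fold higher number from compound 3 to compound 4 (0.10 log units; within the scatter). Compound 4 is estimated at 340 nM, with an expected range of 130 nM to 850 nM.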

Compound 4, half-maximal inhibitory concentration: 224 nM
Beside the measured number, compound 4's estimate is 1.5-fold (0.18 log units) above it; the measured number falls inside the stated range.
By their numbers in this assay, from the lowest: compounds 4 and 3 (each within the scatter of the next); then compound 2; then compound 1.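

In this assay, two different five-membered aromatic rings on a saturated chain carbon bound to a saturated ring carbon cannot be told apart: 2-ethyl-1H-imidazol-1-yl in place of 3-(trifluoromethyl)-1H-1,2,4-triazol-1-yl gives a 1.2-fold lower number from compound 3 to compound 4 (0.08 log units; within the scatter). The same group shows a 2.7-fold lower number from compound 2 to compound 4 (0.43 log units; beyond the scatter) and a 6.3-fold lower number from compound 1 to compound 4 (0.80 log units; beyond the scatter), so both aromatic rings in this set give lower numbers than piperazin-1-yl and dimethylamino. The data shown offer no measurement that accounts for these differences.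

As far as these compounds go, it remains open how the unsubstituted 1H-imidazol-1-yl and 1H-1,2,4-triazol-1-yl groups would compare, and so whether the ethyl or trifluoromethyl substituent matters at all. Also open, from the compounds shown here alone, is how a six-membered aromatic ring such as pyridine or a carboxylic acid would read at this position.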